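The compounds below may be only part of what the source reports. "The series", "measured", "known", "first", "only" and "open" are said of these compounds alone.

Measured so far:
compound 1, `C/C(=N\NC(=O)c1cccc(S(=O)(=O)N2CCOCC2)c1)c1cccc(N)c1`, > 100000 nM
compound 2, `C/C(=N\NC(=O)c1cccc(S(=O)(=O)N2CCOCC2)c1)c1ccc(F)cc1`, > 100000 nM
compound 3, `C/C(=N\NC(=O)c1cccc(S(=O)(=O)N2CCOCC2)c1)c1cc(O)ccc1O`, 21400 nM

In a functional assay on ECa-109 cells for antiproliferative activity against ECa-109 cell line (Homo sapiens), read by MTT assay, with a stated time of 72 h (a lower number here means a stronger inhibitor, a higher number a weaker inhibitor), compound 1 gives > 100000 nM, which is a limit of the assay and not a number. Compound 2 likewise gives only a limit, > 100000 nM. Compound 3 is the single compound of the three with a number in this assay, 21400 nM, so it stands alone at the readable end of what has been shown; the other two sit at the limit of > 100000 nM in this assay, at which 2 of the 3 values shown sit.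

Compound 4, `C/C(=N\NC(=O)c1cccc(S(=O)(=O)N2CCOCC2)c1)c1cccc(N)c1O`, has not yet been measured. It differs from compound 3 by 3-amino-2-hydroxyphenyl in place of 2,5-dihydroxyphenyl on a carbon with a double bond to nitrogen. Among the measured compounds shown here, the steps that bear on this are an at least 4.6-fold lower number from compound 1 to compound 3 (0.66 log units; beyond the scatter) and an at least 4.6-fold lower number from compound 2 to compound 3 (0.66 log units; beyond the scatter); both arrive at the 2,5-dihydroxyphenyl of compound 3 from a ring lacking it and are at least modest. Compound 4 keeps one hydroxyl and takes up an amino group, and compound 1, which carries a 3-aminophenyl, reached only a limit. The expectation for this assay is therefore a step back toward weaker inhibition, estimated as a 2.1-fold higher number from compound 3 to compound 4 (0.32 log units; beyond the scatter), though the two limits leave its size uncertain. Compound 4 is expected to give about 45000 nM, within a range of 12000 nM to 150000 nM.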

Compound 4, half-maximal inhibitory concentration: 5060 nM
For compound 4 the middle estimate is 8.9-fold (0.95 log units) above the measured one, and the stated range ends above it.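

In this assay, 3-amino-2-hydroxyphenyl in place of 2,5-dihydroxyphenyl on a carbon with a double bond to nitrogen gives a 4.2-fold lower number from compound 3 to compound 4 (0.63 log units; beyond the scatter), so this assay separates two groups that match in heavy atoms, hydrogen-bond donors and hydrogen-bond acceptors. An amino group on the ring therefore does not by itself leave a compound at the limit, since hydroxy in place of hydrogen on an aromatic carbon gives an at least 19-fold lower number from compound 1 to compound 4 (1.29 log units; beyond the scatter), and 3-amino-2-hydroxyphenyl in place of 4-fluorophenyl gives an at least 19-fold lower number from compound 2 to compound 4 (1.29 log units; beyond the scatter). Both of these steps start from a limit of the assay and not from a number, so they give only a lower bound on their size: the limit of > 100000 nM in this assay, at which 2 of the 4 values shown sit.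

The compounds shown leave open whether a hydroxy group alone on this ring would give a readable value, or whether the amino group is needed with it. They also leave open how a methoxy group in place of the hydroxy, or an acetamide in place of the amino group, would read in this assay.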